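The source may hold more compounds than are shown below. What is called first, only, known or untested is meant among the compounds shown, and "the series" means these compounds.

The series shares the core of compound 1 `O=C(O)CN1C(=O)/C(=C/C2=Cc3ccccc3OC2)SC1=S`. In a functional assay on MOLT-4 cells (Homo sapiens) for antiproliferative activity, read by MTT assay, with a stated time of 72 h (a lower number here means a stronger inhibitor, a higher number a weaker inhibitor), compound 1 reaches only a limit, > 100000 nM. Compound 2 `O=C1NC(=O)/C(=C/C2=Cc3cc(Br)ccc3OC2)N1` gives 77500 nM in this assay. Compound 3 `O=C(O)CN1C(=O)/C(=C/C2=Cc3cc(Br)ccc3OC2)SC1=S` likewise stops at a limit in this assay, > 25000 nM. Compound 3 therefore stands on a limit rather than a number, and the step that the two limits leave unreadable from compound 1 to compound 3 runs between two limits and cannot be sized. Compound 4 `CC1Oc2ccc(Br)cc2C=C1/C=C1\SC(=S)N(CC(=O)O)C1=O` is still to be measured; it differs from compound 3 by methyl in place of hydrogen on a saturated ring carbon. Among the measured compounds shown here, no measured step carries this change, and the single recorded step is unreadable, so no direction beyond the scatter is expected; the limit at compound 3 the limit of > 25000 nM in this assay, at which 1 of the 3 values shown sits, leaves even the starting point open. Compound 4 is estimated at 30000 nM, between 8000 nM and 100000 nM. The step that the limit leaves unreadable from compound 3 to compound 4 is thus expected to be small.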

Compound 4, half-maximal inhibitory concentration: > 50000 nM
Compound 4: no number, only a limit; the forecaster's own chance of this, stated with the estimate: 60%; middle value at least 1.6-fold (0.22 log units) away from the limit.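

Compound 3 and compound 4 both stop at limits in this assay, so no step can be read between them. The compounds shown leave open how methyl in place of hydrogen on a saturated ring carbon changes activity.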